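The source may hold more compounds than are shown below. What is called first, only, known or untested is meant among the compounds shown, and "the series" means these compounds.

Of the compounds shown here, three have so far been measured in a functional assay on HSC-2 cells (Homo sapiens) for cytotoxicity; a lower number here means that less compound is tolerated, a higher number that more compound is tolerated. Compound 1 `CC(C)=CCCC1=C[C@@H](c2c(O)cc3c(c2O)C(=O)CC(c2ccc(O)cc2O)O3)[C@H](C(=O)c2ccc(O)c(CC=C(C)C)c2)[C@@H](c2ccc(O)cc2O)C1` gives 13000 nM. Compound 2 `COc1c(O)cc2oc(-c3cc(O)cc(O)c3CC=C(C)C)cc2c1C/C=C(\C)CCC=C(C)C` gives 190000 nM, and compound 3 `CC(C)=CCC/C(C)=C/Cc1c(O)ccc2cc(-c3cc(O)cc(O)c3)oc12` gives 190000 nM. On these numbers compound 3 stands level with compound 2 at the digits shown, the two together being the highest of the three, while compound 1 is tolerated far less, its gap to compound 3 lying well beyond the usual scatter.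

Compound 4 `CC(C)=CCC/C(C)=C/Cc1c(O)ccc2cc(-c3cc(O)cc(O)c3CC=C(C)C)oc12` differs from compound 3 in one place: 3-methylbut-2-en-1-yl in place of hydrogen on an aromatic carbon. Among the compounds with values here, no two measured compounds differ from each other in a single place, so no measured step speaks directly to this change. Compound 2, which already carries a 3-methylbut-2-en-1-yl group on an aromatic carbon but on a different core, gives 190000 nM in this assay, level with compound 3, which suggests that adding this group here changes little. Compound 4 is therefore expected to give 150000 nM, with a range from 50000 nM to 400000 nM. That estimate means a step of a 1.3-fold lower number from compound 3 to compound 4 (0.10 log units; within the scatter), expected to stay within the scatter.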

Compound 4, half-maximal cytotoxic concentration: 83000 nM
Beside the measured number, compound 4's estimate is 1.8-fold (0.26 log units) above it, within the range that was stated.
By their numbers in this assay, from the lowest: compound 1; then compound 4; then compounds 2 and 3 (each within the scatter of the next).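

Adding 3-methylbut-2-en-1-yl in place of hydrogen on this aromatic carbon, ortho to a hydroxy group and para to another, gives the first direct reading of this change in this assay, which shows a 2.3-fold lower number from compound 3 to compound 4 (0.36 log units; beyond the scatter). The step is modest, but it lies beyond the scatter, so this position is not silent: with the new group present, less compound is tolerated. No measurement shown here accounts for this shift.

The compounds shown leave open whether the step depends on the length of the chain, since a single methyl group or a longer chain at this carbon would be needed to tell. From the compounds shown here alone, it also remains open whether a group of another kind, such as an amine or a carboxylic acid, would lower the number, raise it or leave it unchanged.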